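Adding tert-butyl to the phenyl urea of compound 2

This account rests on a few compounds, and the source may have more. Where it says the series, first, only, none or still open, it means among the compounds named here.

Measured so far:
compound 1, `CCOc1ccc(NC(=O)Nc2cccc(CNc3nccnc3Cl)c2)cc1`, 9080 nM
compound 2, `O=C(Nc1ccccc1)Nc1cccc(CNc2nccnc2Cl)c1`, 19800 nM
compound 3, `O=C(Nc1cccc(CNc2nccnc2Cl)c1)Nc1ccc(Cl)cc1Br`, 6650 nM

Three ureas sharing one core have been tested in a functional assay on T-24 cells (Homo sapiens) for antiproliferative activity, read by MTT assay, with a stated time of 48 h; on this read-out higher numbers stand for weaker inhibition and lower numbers for stronger inhibition. Compound 2 stands at the highest number of the three: the step from it to its nearest neighbour is a 2.2-fold higher number from compound 1 to compound 2 (0.34 log units; beyond the scatter) read backwards, and the step of a 3.0-fold lower number from compound 2 to compound 3 (0.47 log units; beyond the scatter) takes it to the furthest, both beyond the scatter. Compound 2 is therefore the weakest inhibitor of the set on this read-out.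

Compound 4, `CC(C)(C)c1ccc(NC(=O)Nc2cccc(CNc3nccnc3Cl)c2)cc1`, has not yet been measured. It differs from compound 2 by tert-butyl in place of hydrogen on an aromatic carbon, on an aromatic carbon of a six-membered aromatic ring of carbon only. Going by the values given here, two measured steps bear on this change. The step of a 2.2-fold higher number from compound 1 to compound 2 (0.34 log units; beyond the scatter) shows that removing ethoxy from that same aromatic carbon raised the number; the step of a 3.0-fold lower number from compound 2 to compound 3 (0.47 log units; beyond the scatter) shows that replacing the bare phenyl with a substituted one lowered it. Both substituted analogues, compound 1 and compound 3, gave lower numbers than compound 2, within a modest span.

A modest lowering of the number is therefore expected for compound 4, estimated as a 2.6-fold lower number from compound 2 to compound 4 (0.42 log units; beyond the scatter). The value for compound 4 is estimated at 7500 nM, with a range from 3500 nM to 16000 nM.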

Compound 4, half-maximal inhibitory concentration: 6010 nM
The estimate for compound 4 lay 1.2-fold (0.10 log units) above the measured number; measured number inside the range.
By their numbers in this assay, from the lowest: compounds 4, 3 and 1 (each within the scatter of the next); then compound 2.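

In this assay, tert-butyl on the aromatic carbon para to a large group gives a 3.3-fold lower number from compound 2 to compound 4 (0.52 log units; beyond the scatter), which shows that a purely carbon substituent with no hydrogen-bond donors or acceptors can lower the number at this position, so the oxygen of ethoxy is not required for a step of this kind. Exchanging ethoxy for tert-butyl on that same carbon gives a 1.5-fold lower number from compound 1 to compound 4 (0.18 log units; within the scatter), which lies within the scatter, so this read-out does not separate the two groups, although both compounds stand beyond the scatter from the unsubstituted compound 2. No measurement offered here accounts for these steps.

The compounds shown leave open whether a small alkyl group such as methyl would lower the number as far as tert-butyl does, or whether the step depends on the size of the group. They also leave open what an amine or a carboxylic acid on this same aromatic carbon would do, and so whether any substituent there lowers the number or only some kinds do.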